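This account rests on a few compounds, and the source may have more. Where it says the series, first, only, none or still open, it means among the compounds named here.

Among the compounds with values here, in an ADME assay on L6 cells (Rattus norvegicus) for cytotoxicity, read by resazurin assay, with a stated time of 70 h (on this read-out lower numbers stand for stronger inhibition and higher numbers for weaker inhibition), only two of the three compounds at hand give a number. Compound 2 `COc1cc(CN2c3ccc(OC(C)=O)cc3C(C)=CC2(C)C)cc(OC)c1` gives 25000 nM and compound 3 `CC(=O)Oc1ccc2c(c1)C(C)=CC(C)(C)N2Cc1ccc(C#N)cc1` gives 29000 nM, so compound 3 stands level with compound 2, within the usual scatter of repeated measurements. Compound 1 `CC1=CC(C)(C)N(Cc2cccc(C(F)(F)F)c2)c2ccc(OCc3cccc(C(F)(F)F)c3)cc21` reaches only a limit of this assay, recorded as > 180000 nM.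

The next compound keeps the core of compound 3 and changes one group. Compound 4 `CC(=O)Oc1ccc2c(c1)C(C)=CC(C)(C)N2Cc1ccc(C)cc1` has methyl in place of cyano on an aromatic carbon, para to a large group, so that 4-cyanophenyl becomes 4-methylphenyl (methyl in place of cyano on an aromatic carbon). Within the data shown here, no step between measured compounds that differ in one place is available as a guide. The expectation therefore rests on a looser comparison: compound 2 and compound 3 carry different groups on that ring, yet compound 2 at 25000 nM and compound 3 at 29000 nM lie within the scatter of each other. Compound 1 goes against this closeness, though it also differs elsewhere in its structure. In this assay no change beyond the scatter is therefore expected, in either direction, and the estimated step is no change at the digits printed from compound 3 to compound 4 (within the scatter). For compound 4 the expected value is 29000 nM, with an estimated range of 12000 nM to 70000 nM.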

Compound 4, half-maximal inhibitory concentration: 21000 nM
Compound 4: the middle estimate sits 1.4-fold (0.14 log units) above what was measured; the range from low to high includes it.
By their numbers in this assay, from the lowest: compounds 4, 2 and 3 (each within the scatter of the next). At a limit, above all of these: compound 1.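

Within the data shown here, the step of a 1.4-fold lower number from compound 3 to compound 4 (0.14 log units; within the scatter) in this assay is the first comparison here between compounds that differ in only one place, and it shows that this read-out does not separate 4-cyanophenyl from 4-methylphenyl. The cyano group, with its triple bond and hydrogen-bond acceptor, gives way at this position, para to a large group, to a methyl group that has neither feature, yet the step stays within the usual scatter. Compound 1 remains a limit of the assay and not a number, and it cannot be set against this step: the limit of > 180000 nM in this assay, at which 1 of the 4 values shown sits.

Among these compounds, with only this one change readable at this position, it stays open whether another group in the same place, such as an amine, a carboxylic acid or a longer chain, would move the number in this assay beyond the scatter. The compounds shown also leave open whether methyl in place of cyano would read the same way elsewhere on this ring or on a different core.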